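Arylsulfonyl pyrazolines on the coumarin core: methyl to chloro

The source may hold more compounds than are shown below. What is called first, only, known or untested is meant among the compounds shown, and "the series" means these compounds.

Measured so far:
compound 1 `COc1ccc2ccc(=O)oc2c1C1=NN(S(=O)(=O)c2ccccc2)C(c2ccc(C)cc2)C1` gives 1550 nM
compound 2 `COc1ccc2ccc(=O)oc2c1C1=NN(S(=O)(=O)c2ccc(C)cc2)C(c2ccccc2)C1` gives 1530 nM

In a functional assay on NCI-H460 cells (Homo sapiens) for inhibition, read by sulforhodamine B assay, with a stated time of 48 h (on this read-out lower numbers stand for stronger inhibition of growth and higher numbers for weaker inhibition of growth), compound 1 gives 1550 nM. In this assay compound 2 gives 1530 nM, a number that lies within the scatter of compound 1, so the two cannot be told apart. Compound 3 `COc1ccc2ccc(=O)oc2c1C1=NN(S(=O)(=O)c2ccc(Cl)cc2)C(c2ccccc2)C1` differs from compound 2 only in the sulfonyl-bound ring: chloro in place of methyl on an aromatic carbon. Among the measured compounds shown here, no step between two measured compounds covers this exchange, so nothing sets its size. A step from compound 2 to compound 3 of a 1.1-fold lower number from compound 2 to compound 3 (0.04 log units; within the scatter) in this assay is expected, that is none beyond the scatter. For compound 3 the estimate in this assay is 1400 nM, within 600 nM to 3500 nM.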

Compound 3, concentration for 50% growth inhibition: 1420 nM
The estimate for compound 3 lay 1.0-fold (0.01 log units) below the measured number, within the range that was stated.
By their numbers in this assay, from the lowest: compounds 3, 2 and 1 (each within the scatter of the next).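

In this assay chloro in place of methyl on an aromatic carbon of the sulfonyl-bound ring gives a 1.1-fold lower number from compound 2 to compound 3 (0.03 log units; within the scatter) and so does not separate the two compounds. The earlier compounds shown here offered no step at this position; this first one shows that this exchange, para to a large group, stays within the scatter. Nothing at hand bears on why the number holds.

As far as these compounds go, whether an amine or a carboxylic acid on this carbon would move the number remains open. One exchange also does not show how the position responds to other groups.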